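One Halogen Swap, Seen Twice on a Shared Core

The source may report more compounds than this note shows. Statements on the series, on what has been measured and on what is new or still open speak of the compounds shown alone.

Of the compounds shown here, three sharing one core have been tested in a functional assay on Ehrlich cells (Mus musculus) for cytotoxicity, read by trypan blue exclusion, with a stated time of 48 h; on this read-out higher numbers stand for weaker inhibition and lower numbers for stronger inhibition. Compound 3 `Cc1ccc(-c2csc(NC(=O)COc3ccc(F)cc3)n2)cc1` gives 18100 nM. Compound 1 `Cc1ccc(-c2csc(NC(=O)COc3ccc(Br)cc3)n2)cc1` differs from compound 3 in one place, (bromo in place of fluoro on an aromatic carbon), and this change gave a 2.7-fold higher number from compound 3 to compound 1 (0.43 log units; beyond the scatter). Compound 2 `O=C(COc1ccc(F)cc1)Nc1nc(-c2ccc(Br)cc2)cs1` differs from compound 3 elsewhere, on the core, by bromo in place of methyl on an aromatic carbon; in this assay compound 2 gives 45300 nM, and the step back to compound 3 is a 2.5-fold lower number from compound 2 to compound 3 (0.40 log units; beyond the scatter). Compound 1 gives 48500 nM, a number within the scatter of that of compound 2, so no order between those two can be read.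

Compound 4 `O=C(COc1ccc(Br)cc1)Nc1nc(-c2ccc(Br)cc2)cs1` has not been measured. Within the data shown here, it differs from compound 2 by bromo in place of fluoro on an aromatic carbon, the same change as the one from compound 3 to compound 1, at the same place on the same kind of ring; only the core differs, carrying bromo where compound 3 and compound 1 carry methyl. This change has been seen once, so the expectation rests on a single step. For compound 4 the expected step is a 2.4-fold higher number from compound 2 to compound 4 (0.39 log units; beyond the scatter), read off a 2.7-fold higher number from compound 3 to compound 1 (0.43 log units; beyond the scatter). Compound 4 is therefore estimated at 110000 nM, with a range from 50000 nM to 260000 nM. Because compound 2 already stands at 45300 nM, the expected number is high.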

Compound 4, half-maximal inhibitory concentration: 41100 nM
Beside the measured number, compound 4's estimate is 2.7-fold (0.43 log units) above it; measured number below the stated range.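

In this assay, the swap from 4-fluorophenoxy to 4-bromophenoxy gave a 1.1-fold lower number from compound 2 to compound 4 (0.04 log units; within the scatter) on the core carrying bromo, so the clear step seen on the core carrying methyl did not carry across: the same change on two cores in this assay, a 2.7-fold higher number (0.43 log units; beyond the scatter) from compound 3 to compound 1 and a 1.1-fold lower number (0.04 log units; within the scatter) from compound 2 to compound 4, 3.0-fold (0.47 log units) apart, beyond the scatter of two such steps

The other change, bromo in place of methyl, shows the same dependence on its partner, with a 1.2-fold lower number from compound 1 to compound 4 (0.07 log units; within the scatter) when the phenoxy ring also carries bromo: the same change on two cores in this assay, a 2.5-fold lower number (0.40 log units; beyond the scatter) from compound 2 to compound 3 and a 1.2-fold higher number (0.07 log units; within the scatter) from compound 4 to compound 1, 3.0-fold (0.47 log units) apart, beyond the scatter of two such steps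

Among these four compounds, then, the two changes do not simply add up, and a step measured on one core proved a poor guide to the same step on the other. This rests on only one pair of steps for each change, and it does not show why the steps differ or whether other pairs of groups would behave the same way.

The compounds shown leave open whether a chloro in the same place on the phenoxy ring, or a methoxy in place of the methyl or bromo on the core, would give a step as clear as those from compound 3 or one lost in the scatter. They also leave open what a longer chain in the link between the phenoxy ring and the amide would do to these numbers.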